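This account rests on a few compounds, and the source may have more. Where it says the series, first, only, none or still open, it means among the compounds named here.

Measured in a functional assay on DU-145 cells (Homo sapiens) for antiproliferative activity, read by WST assay, with a stated time of 3 days; a higher number here means a weaker inhibitor, a lower number a stronger inhibitor:
Compound 1 `CCN(CC)CCCCCOc1c(-c2cc(OC)c(OC)c(OC)c2)oc2ccccc2c1=O`: 33400 nM
Compound 2 `CCCCN(CCCC)CCCOc1c(-c2cc(OC)c(OC)c(OC)c2)oc2ccccc2c1=O`: 15700 nM
Compound 3 `CCCCN(CCCC)CCCCCOc1c(-c2cc(OC)c(OC)c(OC)c2)oc2ccccc2c1=O`: > 50000 nM

Compound 3 has no exact number in this assay, only a limit of the assay: the limit of > 50000 nM in this assay, at which 1 of the 3 values shown sits.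

Compound 4 `CCCCCN(CCCCC)CCCOc1c(-c2cc(OC)c(OC)c(OC)c2)oc2ccccc2c1=O` differs from compound 3 in one place: dipentylamino in place of 2-(dibutylamino)ethyl on a saturated chain carbon, three bonds along the chain from an oxygen on an aromatic ring. The two have the same atoms, joined differently.

Among the measured compounds shown here, two measured steps bear on this change. The closer one is an at least 3.1-fold higher number from compound 2 to compound 3 (0.50 log units; beyond the scatter). That step brought in the same 2-(dibutylamino)ethyl group that now leaves, at the same place, and the number went up. The other is a 2.1-fold lower number from compound 1 to compound 2 (0.33 log units; beyond the scatter). There, a plain dibutylamino replaced 2-(diethylamino)ethyl at that place, and the number went down. Both steps lie beyond the scatter, and both suggest that losing the 2-(dialkylamino)ethyl arrangement lowers the number. Dipentylamino itself is still untested, so only a modest gain is expected in this assay. The expected change is an at least 2.7-fold lower number from compound 3 to compound 4 (0.44 log units; beyond the scatter). For compound 4 the estimated value is 18000 nM, with an expected range of 7000 nM to 50000 nM.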

Compound 4, half-maximal inhibitory concentration: 12300 nM
Compound 4: the middle estimate sits 1.5-fold (0.17 log units) above what was measured; low and high end bracket the measured number.
By their numbers in this assay, from the lowest: compounds 4 and 2 (each within the scatter of the next); then compound 1. At a limit, above all of these: compound 3.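

In this assay, compound 3 and compound 4 hold the same atoms joined differently, and exchanging 2-(dibutylamino)ethyl for dipentylamino gives an at least 4.0-fold lower number from compound 3 to compound 4 (0.60 log units; beyond the scatter), a size that is only a floor, since one end of this step is a limit of the assay: the limit of > 50000 nM in this assay, at which 1 of the 4 values shown sits.
Exchanging dibutylamino for dipentylamino at the same place gives a 1.3-fold lower number from compound 2 to compound 4 (0.11 log units; within the scatter), so these two amines cannot be told apart here. The step of a 2.7-fold lower number from compound 1 to compound 4 (0.43 log units; beyond the scatter) is modest, so compound 4 joins compound 2 in improving on compound 1 without showing any further gain.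

On these data alone, whether a ring amine such as piperidine or morpholine would fit this place as well as these open-chain amines remains open. So does whether a still longer dihexylamino group would keep the number at this level.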